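An ethyl group on the aromatic ring of compound 2

This account rests on a few compounds, and the source may have more. Where it says the series, first, only, none or still open, it means among the compounds named here.

- compound 1 `O=C(O)CCCSCCN1C(=O)OC[C@@H]1/C=C/[C@@H](O)Cc1cccc(C(F)(F)F)c1` (6.7%)
- compound 2 `O=C(O)CCCSCCN1C(=O)SC[C@@H]1/C=C/[C@@H](O)Cc1ccccc1` (3.5%)
- compound 3 `Cc1cccc(C[C@H](O)/C=C/[C@H]2CCC(=S)N2CCSCCCC(=O)O)c1` (9.8%)

These three numbers come from an in vivo ADME assay on the whole organism for pharmacokinetics, with Rattus norvegicus as the target, at a dose of 1 mg/kg by the oral route (on this read-out lower numbers stand for lower oral bioavailability and higher numbers for higher oral bioavailability), and lie within the usual scatter of one another. Compound 2 therefore cannot be told apart from compound 1 or compound 3.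

Compound 4 `CCc1cccc(C[C@H](O)/C=C/[C@H]2CSC(=O)N2CCSCCCC(=O)O)c1` is compound 2 with one change: ethyl in place of hydrogen on an aromatic carbon, meta to a large group (ethyl in place of hydrogen on an aromatic carbon). Among the compounds with values here, no measured pair here differs in one place only, so this change has no direct guide. Compound 1 (6.7%) and compound 3 (9.8%) each carry a group on the aromatic ring, but their cores also differ from that of compound 2 (3.5%). In this assay only a small rise, within the scatter, is expected (estimated step a number 2.5 percentage points higher from compound 2 to compound 4 (within the scatter)). The estimate for compound 4 is 6% with an expected range from 2% to 14% in this measurement.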

Compound 4, oral bioavailability: 8.6%
Compound 4: middle estimate off by 2.6 percentage points, on the low side; low and high end bracket the measured number.
By their numbers in this assay, from the lowest: compounds 2, 1, 4 and 3 (each within the scatter of the next).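

Within the data shown here, compound 2 and compound 4 form the first pair here that differs in one place only, and in this assay ethyl in place of hydrogen on an aromatic carbon gives a number 5.1 percentage points higher from compound 2 to compound 4 (within the scatter) on the shared core. At this position, meta to a large group, the ethyl group therefore leaves oral bioavailability indistinguishable from that of the unsubstituted ring, so this single pair shows no clear effect of the change. No accompanying measurement bears on this result.

The compounds shown leave open whether an amine, a methoxy group or a longer chain such as propyl at this same position would give a step beyond the scatter. They also leave open whether ethyl would behave alike on the cores of compound 1 and compound 3.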